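Thiophene for furan at the saturated ring carbon of compound 3

The source may report more compounds than this note shows. Statements on the series, on what has been measured and on what is new or still open speak of the compounds shown alone.

Compound 3 `CC1=C(C(=O)OCC2CC2)C(c2ccoc2)NC(=O)N1` gives 426 nM in an assay on membranes from HEK293 cells for displacement of a labelled ligand from adenosine receptor A2b (Homo sapiens), read by scintillation counting, with a stated time of 30 min; on this read-out lower numbers stand for stronger inhibition and higher numbers for weaker inhibition. Among the three measured compounds it stands second highest: compound 1 `CCCOC(=O)C1=C(C)NC(=O)NC1c1ccsc1` gives 201 nM and compound 2 `CC1=C(C(=O)CC(C)C)C(c2ccoc2)NC(=O)N1` gives 1010 nM in this assay. Among the compounds with values here, the one single-point step in the set, a 2.4-fold lower number from compound 2 to compound 3 (0.37 log units; beyond the scatter), concerns the group on the carbonyl carbon and not the five-membered aromatic ring, so it does not bear on the present change. Compound 4 `CC1=C(C(=O)OCC2CC2)C(c2ccsc2)NC(=O)N1` differs from compound 3 in one place: thiophen-3-yl in place of furan-3-yl on a saturated ring carbon. Within the data shown here, compounds 1 and 3 also differ in this ring, but they differ in the ester group as well, so their two values cannot be split into separate contributions; they show only that the thiophene-bearing compound 1 gives a lower number than compound 3. Among the measured compounds shown here, no measured step therefore maps cleanly onto the furan-to-thiophene exchange, and the expectation rests on the direction indicated by compound 1 alone. A modest lowering is expected for compound 4, of the size a 1.6-fold lower number from compound 3 to compound 4 (0.21 log units; within the scatter). Compound 4 is therefore estimated at 260 nM in this assay, with a range from 120 nM to 560 nM.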

Compound 4, inhibition constant: 724 nM
Estimate against measurement, compound 4: 2.8-fold (0.44 log units) below; measured number outside the range, above it.
By their numbers in this assay, from the lowest: compound 1; then compounds 3, 4 and 2 (each within the scatter of the next, the first and the last beyond it).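

In this assay, thiophen-3-yl in place of furan-3-yl on the saturated ring carbon, with the cyclopropylmethoxy ester held constant, gives a 1.7-fold higher number from compound 3 to compound 4 (0.23 log units; within the scatter), so this pair does not separate the two rings at this position. With thiophen-3-yl held constant, cyclopropyl in place of ethyl in the ester chain gives a 3.6-fold higher number from compound 1 to compound 4 (0.56 log units; beyond the scatter), so among these two thiophene compounds the ester chain carries a step that can be read. No measurement at hand explains either step. On these data alone, it remains open whether the furan-to-thiophene exchange reads the same with the propyl ester of compound 1. Also open, as far as these compounds go, is how a phenyl ring on the saturated ring carbon, or a longer chain in the ester, would compare with these compounds.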